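This account rests on a few compounds, and the source may have more. Where it says the series, first, only, none or still open, it means among the compounds named here.

Compound 1 `Cc1ccc(Cl)cc1Nc1nc(C(F)(F)F)ccc1CNC(=O)C(C)c1ccc(NS(C)(=O)=O)c(F)c1` carries a (5-chloro-2-methylphenyl)amino group on the shared core. Within the data shown here, in a functional assay on CHO-K1 cells for antagonist activity at transient receptor potential cation channel subfamily V member 1 (Homo sapiens), read by FLIPR (a lower number here means a stronger inhibitor, a higher number a weaker inhibitor), compound 1 gives 14 nM, the higher of the two numbers measured so far, which makes it the weaker of the two inhibitors. Compound 2 `CCCCN(C)c1nc(C(F)(F)F)ccc1CNC(=O)C(C)c1ccc(NS(C)(=O)=O)c(F)c1` carries butyl(methyl)amino in that place, and in this assay compound 2 gives 0.8 nM. Among the measured compounds shown here, the single measured step, an 18-fold lower number from compound 1 to compound 2 (1.24 log units; beyond the scatter), shows that exchanging the arylamino group for a nitrogen bearing two alkyl carbons lowers the number substantially.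

Compound 3 `CC(C)OC1CCN(c2nc(C(F)(F)F)ccc2CNC(=O)C(C)c2ccc(NS(C)(=O)=O)c(F)c2)CC1` is not yet measured. It differs from compound 1 in one place: 4-isopropoxypiperidin-1-yl in place of (5-chloro-2-methylphenyl)amino on an aromatic carbon As in compound 2, the nitrogen in compound 3 bears two alkyl carbons, though here it sits in a six-membered non-aromatic ring with 1 hetero atom and carries an isopropoxy substituent. Because an 18-fold lower number from compound 1 to compound 2 (1.24 log units; beyond the scatter) was large, a lower number is expected for compound 3 as well, perhaps a somewhat smaller drop given the different shape of the entering group, giving the expected step of a 7.0-fold lower number from compound 1 to compound 3 (0.85 log units; beyond the scatter). For compound 3 in this assay the estimate is 2 nM, with a likely range from 0.5 nM to 8 nM.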

Compound 3, inhibition constant: 3 nM
Estimate against measurement, compound 3: 1.5-fold (0.18 log units) below; low and high end bracket the measured number.
By their numbers in this assay, from the lowest: compound 2; then compound 3; then compound 1.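

The 4-isopropoxypiperidin-1-yl group also beats the (5-chloro-2-methylphenyl)amino group in this assay, with a 4.7-fold lower number from compound 1 to compound 3 (0.67 log units; beyond the scatter), so the lower number is not confined to the open butyl(methyl)amino chain: it also appears when the attached nitrogen belongs to a six-membered non-aromatic ring carrying an isopropoxy group. The two replacements are still not interchangeable at this position, as a 3.8-fold higher number from compound 2 to compound 3 (0.57 log units; beyond the scatter) shows that the ring gives up part of the gain and leaves compound 2 as the strongest inhibitor of the three. No supporting measurement is available to explain either step.

The piperidine ring and its isopropoxy group enter together, so the compounds shown cannot say which of the two accounts for the gap between compound 2 and compound 3; a plain piperidin-1-yl group, without the isopropoxy, would separate them. A butylamino group, which keeps a hydrogen on the attached nitrogen, would likewise show whether the gain from compound 1 to compound 2 follows the alkyl chain or the loss of that hydrogen.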